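From a ring group to benzoyl: estimating compound 4

The source may hold more compounds than are shown below. What is called first, only, known or untested is meant among the compounds shown, and "the series" means these compounds.

- compound 1 `Cn1nnc(-c2cc(-c3ccccc3)c3ccc(OCc4cccc(C5(O)CCOCC5)c4)cc3c2)n1`: 4 nM
- compound 2 `OC1(c2cccc(COc3ccc4c(-c5ccoc5)cc(C5=NCCO5)cc4c3)c2)CCOCC1`: 3 nM
- compound 3 `CC1(C)COC(c2cc(-c3ccoc3)c3ccc(OCc4cccc(C5(O)CCOCC5)c4)cc3c2)=N1`: 17 nM

In a functional assay for inhibition, with Homo sapiens as the target (on this read-out lower numbers stand for stronger inhibition and higher numbers for weaker inhibition), compound 3 gives 17 nM, the highest number of the three, so it is the weakest inhibitor here. The values of compound 1 and compound 2 lie close together.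

Compound 4 `O=C(c1ccccc1)c1cc(-c2ccoc2)c2ccc(OCc3cccc(C4(O)CCOCC4)c3)cc2c1` has not yet been measured. It loses the five-membered non-aromatic ring group of compound 3 and carries a benzoyl group on the same aromatic carbon, meta to the furan-3-yl group: a group of 8 heavy atoms (7 carbon, 1 oxygen; one six-membered aromatic ring of carbon only) in place of a group of 7 heavy atoms (5 carbon, 1 nitrogen, 1 oxygen; one five-membered non-aromatic ring with 2 hetero atoms), on an aromatic carbon.

Within the data shown here, only one measured step touches this carbon: a 5.7-fold higher number from compound 2 to compound 3 (0.75 log units; beyond the scatter). That step is modest but beyond the scatter, so the group at this place can move the number. Among the measured compounds shown here, it still exchanges one five-membered non-aromatic ring group for another, and no measured compound carries a benzoyl group. Compound 1 has a different group at this carbon and also differs elsewhere, and it reaches 4 nM.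

With so little direct evidence, no step beyond the scatter is expected in this assay. The estimated step is a 1.4-fold lower number from compound 3 to compound 4 (0.15 log units; within the scatter). For compound 4 the estimated value is 12 nM, with an expected range from 3 nM to 50 nM.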

Compound 4, half-maximal inhibitory concentration: 1 nM
Compound 4: the middle estimate sits 12-fold (1.08 log units) above what was measured, outside the stated range (below it).
By their numbers in this assay, from the lowest: compound 4; then compounds 2 and 1 (each within the scatter of the next); then compound 3.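

In this assay, this aromatic carbon does not depend on a five-membered non-aromatic ring with 2 hetero atoms: swapping that group for benzoyl, which has a six-membered aromatic ring of carbon only and no ring nitrogen, gives a 17-fold lower number from compound 3 to compound 4 (1.23 log units; beyond the scatter) and is a large step. Benzoyl also does better than the smaller ring group of compound 2, with a 3.0-fold lower number from compound 2 to compound 4 (0.48 log units; beyond the scatter) as the comparison, so the earlier step between the two ring groups did not mark the best that this place can reach. No measurement here bears on this gain.

As far as these compounds go, what remains open is which part of benzoyl matters, since a plain phenyl group or an acetyl group on this carbon would separate the aromatic ring from the carbonyl. It is also unknown whether benzoyl would give the same gain if the furan-3-yl group were replaced by another group, such as the phenyl ring found in compound 1.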